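Swapping a thiophene substituent on an imidazole-bearing biaryl

This account rests on a few compounds, and the source may have more. Where it says the series, first, only, none or still open, it means among the compounds named here.

Measured so far:
- compound 1, `CCC(c1ccc(-c2cscc2C)cc1)n1ccnc1`: 27%
- compound 2, `c1cn(Cc2ccc(-c3ccoc3)cc2)cn1`: 3%
- compound 3, `COc1ccc(-c2csc(Cn3ccnc3)c2)cc1OC`: 0%

Of the compounds shown here, three have been tested in an assay for inhibition of steroid 17-alpha-hydroxylase/17,20 lyase (Homo sapiens), using NADPH, tested at 0.2 uM; a lower number here means a weaker effect, a higher number a stronger effect of the compound at the concentration tested. Compound 1 stands highest of the three, and its distance to both compound 2 and compound 3 lies beyond the usual scatter, so among these it is the strongest. Compound 2 and compound 3 show little or no inhibition in this assay.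

The next compound, compound 4, `CCC(c1ccc(-c2ccsc2Cl)cc1)n1ccnc1`, keeps the core of compound 1 and changes only the ring attached to it: 2-chlorothiophen-3-yl in place of 4-methylthiophen-3-yl on an aromatic carbon. Within the data shown here, no pair of measured compounds differs in just one place, so there is no measured step to lean on. The change is small in size, and the expectation is a step of modest size in this assay, with no clear direction. The estimate for compound 4 is 25% (range 5% to 50%), which means an expected step of a number 2 percentage points lower from compound 1 to compound 4 (within the scatter).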

Compound 4, a percentage reported as inhibition, at one concentration (the size of the read-out at that concentration, not a potency): 40%
Compound 4: the middle estimate sits 15 percentage points below what was measured; measured number inside the range.
By their numbers in this assay, from the lowest: compounds 3 and 2 (each within the scatter of the next); then compound 1; then compound 4.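

Among these compounds, this is the first pair of compounds that differ in only one place: in this assay, placing 2-chlorothiophen-3-yl in place of 4-methylthiophen-3-yl gives a number 13 percentage points higher from compound 1 to compound 4 (beyond the scatter). The read-out therefore responds to a swap at this position on the six-membered aromatic ring, even though both groups are five-membered aromatic rings with the same counts of heavy atoms and hydrogen-bond acceptors. Nothing in the available data explains the rise.

This single swap changes both the substituent and its place on the thiophene, so the data cannot separate the contribution of the chlorine from that of its location. Going by these compounds, how a bromine, a nitrile or an amine on the thiophene would compare also remains open.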